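Changing the aromatic group on the ring nitrogen

The source may report more compounds than this note shows. Statements on the series, on what has been measured and on what is new or still open speak of the compounds shown alone.

Of the compounds shown here, three that share one core have been tested in a functional assay on CHO cells with adenosine receptor A1 (Homo sapiens) as the target, read by cAMP accumulation and immunoassay, with a stated time of 6 min, tested at 0.01 uM; on this read-out higher numbers stand for a weaker effect at the one concentration tested and lower numbers for a stronger effect. Compound 1 `Nc1scc(CN2CCN(c3ccc([N+](=O)[O-])cc3)CC2)c1C(=O)c1ccc(Cl)cc1` gives -12%, compound 2 `Nc1scc(CN2CCN(c3ccccc3C(F)(F)F)CC2)c1C(=O)c1ccc(Cl)cc1` gives 0%, and compound 3 `Nc1scc(CN2CCN(c3ccc(F)c(Cl)c3)CC2)c1C(=O)c1ccc(Cl)cc1` gives 4.2%. Compound 3 thus holds the highest of the three numbers in this assay. The measured steps are a number 12 percentage points higher from compound 1 to compound 2 (beyond the scatter), a number 16.2 percentage points higher from compound 1 to compound 3 (beyond the scatter) and a number 4.2 percentage points higher from compound 2 to compound 3 (within the scatter); the first two lie beyond the scatter, the third within it, so compound 3 and compound 2 cannot be told apart on this read-out.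

Compound 4 `Nc1scc(CN2CCN(c3cc(Cl)ccc3Cl)CC2)c1C(=O)c1ccc(Cl)cc1` has not yet been measured. It differs from compound 3 in one place: 2,5-dichlorophenyl in place of 3-chloro-4-fluorophenyl on an amine nitrogen in a ring. The step that bears most directly on this change is a number 4.2 percentage points higher from compound 2 to compound 3 (within the scatter), in which one aromatic group on the same ring nitrogen was replaced by another and the read-out stayed within the scatter. The two larger steps, a number 12 percentage points higher from compound 1 to compound 2 (beyond the scatter) and a number 16.2 percentage points higher from compound 1 to compound 3 (beyond the scatter), both involve the 4-nitrophenyl group, which plays no part in the present change. On this basis no step beyond the scatter is expected in this assay. The estimated step is a number 1.2 percentage points lower from compound 3 to compound 4 (within the scatter). Compound 4 is therefore expected to give about 3% in this assay, within a range from -10% to 16%.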

Compound 4, a percentage reported as activity, at one concentration (the size of the read-out at that concentration, not a potency): 13%
Compound 4: the middle estimate sits 10 percentage points below what was measured; the range from low to high includes it.
By their numbers in this assay, from the lowest: compound 1; then compounds 2, 3 and 4 (each within the scatter of the next, the first and the last beyond it).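

In this assay, replacing 3-chloro-4-fluorophenyl with 2,5-dichlorophenyl, which has the same count of heavy atoms, gives a number 8.8 percentage points higher from compound 3 to compound 4 (within the scatter), so this change on the ring nitrogen leaves the read-out within the scatter. Among the compounds shown here, what the earlier compounds did not show is a separation among the halogen-bearing groups at this position: the step of a number 13 percentage points higher from compound 2 to compound 4 (beyond the scatter) lies beyond the scatter, although compound 3 cannot be told apart from compound 2 or from compound 4, so these three compounds form a chain rather than one tight cluster. The step of a number 25 percentage points higher from compound 1 to compound 4 (beyond the scatter) also lies beyond the scatter, which means that compound 4, like compound 2 and compound 3, stands apart from the 4-nitrophenyl compound 1.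

No available evidence explains why these aromatic groups differ on this read-out. The compounds shown leave open how the read-out would respond to an unsubstituted phenyl, a pyridine ring or a benzyl group on the same ring nitrogen, and whether a carboxylic acid or an amine on the phenyl ring would extend the range seen here.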